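The source may report more compounds than this note shows. Statements on the series, on what has been measured and on what is new or still open speak of the compounds shown alone.

Compound 1 `COc1ccc2c(c1)OC(N)=C(C#N)C2c1cccc(Br)c1` carries a 3-bromophenyl group on a fused two-ring core. In a functional assay on T47D cells (Homo sapiens) for activation (on this read-out higher numbers stand for an effect only at larger amounts of compound and lower numbers for an effect already at smaller amounts), compound 1 gives 52000000 nM, the second highest of three numbers. Compound 3 `COc1ccc2c(c1)OC(N)=C(C#N)C2c1cccc([N+](=O)[O-])c1` gives 88900000 nM in this assay, and the step of a 1.7-fold higher number from compound 1 to compound 3 (0.23 log units; within the scatter) lies within the scatter. Compound 2 `COc1cc(C2C(C#N)=C(N)Oc3c2ccc(N)c3N)cc(Cl)c1OC` gives 24000000 nM, a lower number that lies beyond the scatter from compound 1. Compound 4 `COc1ccc2c(c1)OC(N)=C(C#N)C2c1cccnc1` differs from compound 1 by pyridin-3-yl in place of 3-bromophenyl on a saturated ring carbon. Among the compounds with values here, the only measured step touching that aromatic ring changed a substituent, not the ring itself, and it stayed within the scatter; no measured step swaps the ring. The expected step of no change at the digits printed from compound 1 to compound 4 (within the scatter) is therefore small, without a clear direction. Compound 4 is estimated at 52000000 nM, expected between 15000000 nM and 180000000 nM.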

Compound 4, half-maximal effective concentration: 170000000 nM
Compound 4: the middle estimate sits 3.3-fold (0.51 log units) below what was measured, within the range that was stated.
By their numbers in this assay, from the lowest: compound 2; then compounds 1, 3 and 4 (each within the scatter of the next, the first and the last beyond it).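

Replacing the whole aromatic ring on this saturated ring carbon does shift the read-out: pyridin-3-yl in place of 3-bromophenyl gives a 3.3-fold higher number from compound 1 to compound 4 (0.51 log units; beyond the scatter) in this assay, so compound 4 needs larger amounts for an effect. The earlier change of a substituent alone, a 1.7-fold higher number from compound 1 to compound 3 (0.23 log units; within the scatter), stayed within the scatter. Nothing here explains the shift. Still open, on these data alone, is whether gaining the ring nitrogen or losing the bromine drives this step, and whether a carboxylic acid or a longer chain on this carbon would lower the number.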